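The source may report more compounds than this note shows. Statements on the series, on what has been measured and on what is new or still open speak of the compounds shown alone.

Three compounds share one core, each carrying two double-bonded arms that end in an aromatic ring. Compound 1 `COc1ccccc1/C=c1/[nH]c(=O)/c(=C\c2ccccc2OC)n(C)c1=O` has 2-methoxyphenyl on both arms; in a functional assay on HeLa cells (Homo sapiens) for cytotoxicity, read by CCK-8 assay, with a stated time of 72 h (on this read-out higher numbers stand for weaker inhibition and lower numbers for stronger inhibition), compound 1 gives "not active" (no number reported), with no number reported. Compound 2 `C=CCn1c(=O)/c(=C\c2cc(Br)ccc2F)[nH]c(=O)/c1=C\c1ccccc1OC` differs from compound 1 in more than one place and pairs a 2-methoxyphenyl arm with a 5-bromo-2-fluorophenyl arm; in this assay compound 2 gives 34600 nM, the only number among these entries, so it cannot be ranked against anything. Compound 3 `C=CCn1c(=O)/c(=C\c2ccccc2OC)[nH]c(=O)/c1=C\c1ccccc1OC` differs from compound 2 in one place only: 2-methoxyphenyl in place of 5-bromo-2-fluorophenyl on a double-bonded chain carbon bound to an aromatic carbon. Going by the values given here, no two measured compounds differ in a single place, so no measured step shows what this exchange does on its own. Among the compounds with values here, the one hint is compound 1, which also carries 2-methoxyphenyl on both arms and gives "not active" (no number reported) in this assay. The expected step from compound 2 to compound 3 is therefore toward weaker inhibition, beyond the scatter a 2.0-fold higher number from compound 2 to compound 3 (0.31 log units; beyond the scatter), possibly to no number at all. Compound 3 is estimated at 70000 nM in this assay, within a range from 25000 nM to 250000 nM.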

Compound 3, half-maximal inhibitory concentration: 6900 nM
The estimate for compound 3 lay 10-fold (1.01 log units) above the measured number; measured number below the stated range.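

In this assay the exchange of 5-bromo-2-fluorophenyl for 2-methoxyphenyl on a double-bonded chain carbon bound to an aromatic carbon brings a 5.0-fold lower number from compound 2 to compound 3 (0.70 log units; beyond the scatter) and so moves this pair toward stronger inhibition, a modest gain that lies beyond the usual scatter. This position therefore responds to the group it carries, and here the arm with the methoxy group does better than the arm with two halogens. Compound 1 and compound 3 both carry 2-methoxyphenyl on both arms, yet compound 1 gives "not active" (no number reported) while compound 3 gives 6900 nM and so having this group on both arms does not by itself mean that no number is obtained; nothing shown gives a measured reason for the step from 5-bromo-2-fluorophenyl to 2-methoxyphenyl.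

This single exchange removes bromine and fluorine and adds a methoxy group all at once, so the compounds shown cannot say which of these changes matters. Also open, on these data alone, is how this position would respond to a plain phenyl ring, or to a phenyl ring carrying an amine or a carboxylic acid.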